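The source may hold more compounds than are shown below. What is called first, only, known or untested is meant among the compounds shown, and "the series" means these compounds.

Working notes on the series. In a physicochemical assay for lipophilicity, at pH 7.4 (on this read-out higher numbers stand for higher lipophilicity and lower numbers for lower lipophilicity), compound 1 `CNC(=O)c1cc(C(=O)NC2CC2)cn(Cc2ccc(OC)cc2)c1=O` gives 3 and compound 2 `CNC(=O)c1cc(C(=O)NC2CC2)c(C)n(Cc2ccccc2)c1=O` gives 2.9. These two values lie within the scatter of each other, so compound 1 stands level with compound 2 and no order can be drawn between them. Compound 3 `CNC(=O)c1cc(C(=O)NC2CC2)cn(Cc2cccc3[nH]ccc23)c1=O` differs from compound 1 by a single change: 1H-indol-4-yl in place of 4-methoxyphenyl on a saturated chain carbon bound to an aromatic nitrogen. Among the compounds with values here, no measured pair shows a change of this kind, so no step beyond the scatter is expected in this assay, in either direction. The estimated step is a number 0.10 log units lower from compound 1 to compound 3 (within the scatter). For compound 3 the estimated value is 2.9, with an expected range of 2.5 to 3.3.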

Compound 3, distribution coefficient: 2.9
Compound 3: middle estimate and measured number agree at the digits printed; low and high end bracket the measured number.
By their numbers in this assay, from the lowest: compounds 2, 3 and 1 (each within the scatter of the next).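

In this assay, going over from the 4-methoxyphenyl group to the 1H-indol-4-yl group gives a number 0.10 log units lower from compound 1 to compound 3 (within the scatter) as the first step read at this position. The exchange of one aromatic group for another, with a hydrogen-bond donor entering and a hydrogen-bond acceptor leaving, thus leaves the read-out level. No independent data bear on this result. On these data alone, what a carboxylic acid or an amine at this place would do to the number remains open, as does whether this level reading holds on any core other than that of compound 1.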